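Fluoro for Bromo on the Shared Core

A few compounds are considered here, and "the series" means these few. Any claim that something is new, unique, unknown or untested is made for them only; others in the source may bear on it.

Among the compounds with values here, compound 1 `O=C1c2cccc([N+](=O)[O-])c2NC[C@@]12[C@H](c1ccc(Br)cc1)[C@@H](c1ccccc1)N[C@]21C(=O)Nc2ccc(Br)cc21` stands at the higher of the two numbers measured so far: in a functional assay on HeLa cells (Homo sapiens) for cytotoxicity, read by MTT assay, with a stated time of 72 h (a lower number here means a stronger inhibitor, a higher number a weaker inhibitor), compound 1 gives 25000 nM. Its nearest neighbour is compound 2 `COc1ccc([C@@H]2[C@@H](c3ccccc3)N[C@]3(C(=O)Nc4ccc(Br)cc43)[C@]23CNc2c(cccc2[N+](=O)[O-])C3=O)cc1`, which in this assay gives 19000 nM; the step of a 1.3-fold lower number from compound 1 to compound 2 (0.12 log units; within the scatter) is within the scatter, so the two compounds cannot be told apart on this read-out. Compound 3 `O=C1c2cccc([N+](=O)[O-])c2NC[C@@]12[C@H](c1ccc(Br)cc1)[C@@H](c1ccccc1)N[C@]21C(=O)Nc2ccc(F)cc21` has not yet been measured. Relative to compound 1 it carries fluoro in place of bromo on an aromatic carbon. Within the data shown here, no measured step touches this position; the only step known, a 1.3-fold lower number from compound 1 to compound 2 (0.12 log units; within the scatter), sits on a different ring and stays within the scatter. Nothing in the data points to a direction, so a step of no change at the digits printed from compound 1 to compound 3 (within the scatter) is expected, none beyond the scatter. The estimate for compound 3 in this assay is 25000 nM, with a range from 10000 nM to 60000 nM.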

Compound 3, half-maximal inhibitory concentration: 26000 nM
The estimate for compound 3 lay 1.0-fold (0.02 log units) below the measured number; the range from low to high includes it.
By their numbers in this assay, from the lowest: compounds 2, 1 and 3 (each within the scatter of the next).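

This change falls on the ring that the step to compound 2 left untouched, on an aromatic carbon meta to a fused ring and para to a fused ring. In this assay fluoro in place of bromo gives a 1.0-fold higher number from compound 1 to compound 3 (0.02 log units; within the scatter) and so leaves the two compounds indistinguishable on this read-out. At this position, then, one halogen can stand in for the other without a step beyond the scatter, and nothing available explains this result.

As far as these compounds go, whether an amine, a carboxylic acid or a longer chain at this aromatic carbon would shift the number beyond the scatter remains open. The compounds shown also leave open whether any change to the shared core can do so, since all three lie within the scatter of one another.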